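Replacing One Aromatic Group on Compound 2

The source may report more compounds than this note shows. Statements on the series, on what has been measured and on what is new or still open speak of the compounds shown alone.

In a functional assay on MDA-MB-231 cells (Homo sapiens) for antiproliferative activity, read by MTT assay, with a stated time of 48 h (on this read-out lower numbers stand for stronger inhibition and higher numbers for weaker inhibition), compound 1 `C=CS(=O)(=O)N1CCN(c2ccn3ncc(-c4ccccc4)c3n2)CC1` gives 38300 nM and compound 3 `C=CS(=O)(=O)N1CCN(c2ncnc3sc(-c4cn(S(=O)(=O)c5ccccc5)c5ccccc45)cc23)CC1` gives 40400 nM while compound 2 `C=CS(=O)(=O)N1CCN(c2ncnc3sc(-c4ccc(C(F)(F)F)cc4)cc23)CC1` gives 6410 nM as the lowest number of the three. The gaps from compound 2 to the other two both lie beyond the usual scatter of repeated measurements. No two of these compounds differ in just one place, so no single change has been measured directly.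

Compound 4 `C=CS(=O)(=O)N1CCN(c2ncnc3sc(-c4ccnc(Cl)c4)cc23)CC1` is still unmeasured. It has 2-chloropyridin-4-yl in place of the 4-(trifluoromethyl)phenyl of compound 2 on an aromatic carbon next to the ring sulfur 2-chloropyridin-4-yl in place of 4-(trifluoromethyl)phenyl on an aromatic carbon and keeps the rest of the structure.

With compound 2 already lowest at 6410 nM a move upward seems likelier than a move downward. Compound 3 has the same core with another group on that carbon and reads 40400 nM so a large rise cannot be ruled out. The expected change is a 2.0-fold higher number from compound 2 to compound 4 (0.31 log units; beyond the scatter) toward weaker inhibition, modest in size. Compound 4 is estimated at 13000 nM with 4000 nM to 40000 nM as its expected span.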

Compound 4, half-maximal inhibitory concentration: 27700 nM
Estimate against measurement, compound 4: 2.1-fold (0.33 log units) below; the range from low to high includes it.
By their numbers in this assay, from the lowest: compound 2; then compounds 4, 1 and 3 (each within the scatter of the next).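

In this assay, exchanging 4-(trifluoromethyl)phenyl for 2-chloropyridin-4-yl on the aromatic carbon next to the ring sulfur gives a 4.3-fold higher number from compound 2 to compound 4 (0.64 log units; beyond the scatter). For the compounds shown here, this is the first direct reading of a single change at this position, and it shows that the number responds when one six-membered aromatic ring is exchanged for another on an otherwise unchanged compound. Nothing measured here bears on why the number rises.

On these data alone, the two groups differ in the ring nitrogen, the chlorine and the trifluoromethyl all at once, so the share of each in this step stays open. Also open, as far as these compounds go, is how this carbon would read with a pyridine ring lacking the chlorine, or with a phenyl ring carrying an amine or a carboxylic acid.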